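The compounds below may be only part of what the source reports. "The series", "measured", "known", "first", "only" and "open" are said of these compounds alone.

All values below come from a functional assay on A549 cells (Homo sapiens) for inhibition, read by sulforhodamine B assay, with a stated time of 72 h; a higher number here means a weaker inhibitor, a lower number a stronger inhibitor.

Measured compounds:
compound 1 `Nc1sc(-c2ccc(Cl)cc2)c(-c2ccc(Cl)cc2)c1C(=O)NC1CCCCC1`: 2410 nM
compound 2 `Nc1sc(-c2ccc(Cl)cc2)c(-c2ccc(Cl)cc2)c1C(=O)N1CCNCC1`: 1020 nM
compound 3 `Nc1sc(-c2ccc(Cl)cc2)c(-c2ccc(Cl)cc2)c1C(=O)NC1CCCC1`: 6790 nM

Compound 1 stands second highest of the three numbers. Its nearest neighbour is reached by a 2.4-fold lower number from compound 1 to compound 2 (0.37 log units; beyond the scatter) and its furthest by a 2.8-fold higher number from compound 1 to compound 3 (0.45 log units; beyond the scatter); the two other measured compounds also stand apart from each other, by a 6.7-fold higher number from compound 2 to compound 3 (0.82 log units; beyond the scatter).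

Compound 4 `COc1ccc(CNC(=O)c2c(N)sc(-c3ccc(Cl)cc3)c2-c2ccc(Cl)cc2)cc1` differs from compound 1 in one place: 4-methoxybenzyl in place of cyclohexyl on an amide-type nitrogen. All measured steps change the same amide substituent, so all bear on this one, but none of them exchanges a saturated ring for a benzyl group. Among the compounds with values here, the closest precedent, a cyclopentyl in place of the cyclohexyl, gave a modest rise; the piperazine gave a modest fall. The direction of the new step is therefore unsettled, and the expected step in this assay is a 1.0-fold higher number from compound 1 to compound 4 (0.02 log units; within the scatter), small and within the scatter, with a wide range to either side. For compound 4 the estimate is 2500 nM, expected to fall between 700 nM and 9000 nM.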

Compound 4, half-maximal inhibitory concentration: 18200 nM
Beside the measured number, compound 4's estimate is 7.3-fold (0.86 log units) below it, and the stated range ends below it.
By their numbers in this assay, from the lowest: compound 2; then compound 1; then compound 3; then compound 4.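

In this assay, the substituent on the amide-type nitrogen can raise the number further than the cyclopentyl change suggested: 4-methoxybenzyl in place of cyclohexyl gives a 7.6-fold higher number from compound 1 to compound 4 (0.88 log units; beyond the scatter). The benzyl amide also stands apart from the cyclopentyl amide, with a 2.7-fold higher number from compound 3 to compound 4 (0.43 log units; beyond the scatter), and from the piperazine amide, with an 18-fold higher number from compound 2 to compound 4 (1.25 log units; beyond the scatter), the only large step here, which makes compound 4 the weakest of the four shown. No available evidence accounts for this rise.

An unsubstituted benzyl group on the same nitrogen would show whether the rise follows the benzyl group itself or its methoxy substituent. A morpholine in place of the piperazine would show whether the second ring nitrogen matters to the lowest number in the set.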